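This account rests on a few compounds, and the source may have more. Where it says the series, first, only, none or still open, it means among the compounds named here.

Working notes on the series. In an ADME assay on HCT-116 cells (Homo sapiens) for cytotoxicity, read by MTT assay, with a stated time of 72 h (a higher number here means a weaker inhibitor, a lower number a stronger inhibitor), compound 3 `CCc1cccc(NC(=O)c2cccc(/C=C3\CC(=O)N(c4ccccc4)C3=O)c2)c1` gives 81200 nM, the highest of the two numbers recorded, with compound 2 `CCc1cccc(NC(=O)c2cccc(/C=C3\CC(=O)N(Cc4ccccc4)C3=O)c2)c1` nearest at 80600 nM. For the measured compounds named here, the one measured step, a 1.0-fold higher number from compound 2 to compound 3 (0.00 log units; within the scatter), changes the same ring nitrogen and left the number unchanged within the scatter. Compound 1 `CCCCCN1C(=O)C/C(=C\c2cccc(C(=O)Nc3ccc(C)cc3)c2)C1=O` in this assay gives > 100000 nM, which is a limit of the assay rather than a number (the limit of > 100000 nM in this assay, at which 1 of the 3 values shown sits).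

Compound 4 `CCCCCN1C(=O)C/C(=C\c2cccc(C(=O)Nc3cccc(CC)c3)c2)C1=O` has not yet been measured in this assay. It differs from compound 3 by pentyl in place of phenyl on an amide-type nitrogen in a ring. Going by the values given here, no measured step swaps phenyl for pentyl at this nitrogen, so the expectation rests on two observations: the only step at this position, a 1.0-fold higher number from compound 2 to compound 3 (0.00 log units; within the scatter), was within the scatter, and compound 1, which carries pentyl on the same nitrogen with a methyl anilide, reports only a limit. The step of a 1.2-fold higher number from compound 3 to compound 4 (0.09 log units; within the scatter) is therefore expected to be small or upward, and a limit rather than a number is a real possibility. Compound 4 is estimated at 100000 nM, with a range from 60000 nM to 200000 nM.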

Compound 4, half-maximal inhibitory concentration: 75300 nM
For compound 4 the middle estimate is 1.3-fold (0.12 log units) above the measured one; the measured number falls inside the stated range.
By their numbers in this assay, from the lowest: compounds 4, 2 and 3 (each within the scatter of the next). At a limit, above all of these: compound 1.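

In this assay, pentyl, phenyl and benzyl on the amide-type nitrogen in the ring now stand within the scatter of one another: a 1.1-fold lower number from compound 3 to compound 4 (0.03 log units; within the scatter), and a 1.1-fold lower number from compound 2 to compound 4 (0.03 log units; within the scatter). Pentyl at this nitrogen thus gives a measured number in compound 4, so pentyl alone does not go with a limit in this pair of compounds. Compound 1 remains a limit and not a number, and its step at the anilide, an at least 1.3-fold lower number from compound 1 to compound 4 (0.12 log units; that floor lies within the scatter), has a floor that does not separate 3-ethylphenyl from 4-methylphenyl.

The compounds shown leave open whether an amine or a carboxylic acid on a chain at this nitrogen would move the number beyond the scatter. On these data alone, a longer chain than pentyl at the same place also remains open.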